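Adding a Methylcyclopropyl Group to an Amide Nitrogen

The source may report more compounds than this note shows. Statements on the series, on what has been measured and on what is new or still open speak of the compounds shown alone.

Of the compounds shown here, three sharing one core have been measured in a physicochemical assay for solubility; on this read-out lower numbers stand for lower solubility and higher numbers for higher solubility. Compound 1 `CNC(=O)c1cc(C(=O)N[C@H]2[C@@H]3COC[C@@H]32)cc2c1OC[C@H]2c1ccccc1` gives a value that is only a limit of the assay, >= 165 ug/mL. Compound 2 `CNC(=O)c1cc(C(=O)N[C@H]2[C@@H]3COC[C@@H]32)cc2c1OC[C@H]2c1cccnc1` likewise gives only a limit, >= 104 ug/mL. Among the compounds with values here, the one single-point step among the measured compounds, a step that the two limits leave unreadable from compound 1 to compound 2, is therefore not readable in size. Compound 3 `CNC(=O)c1cc(C(=O)NC)c2c(c1)[C@](C)(c1ccccc1)CO2` also sits at a limit, >= 132 ug/mL, so its true solubility is not known as a number, only as being at or beyond that point.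

Compound 4 `CNC(=O)c1cc(C(=O)N[C@H]2C[C@@H]2C)cc2c1OC[C@@]2(C)c1ccccc1` differs from compound 3 at one place: 2-methylcyclopropyl in place of methyl on an amide-type nitrogen. Within the data shown here, no measured step in this assay bears on this kind of change, since the only step recorded concerns pyridin-3-yl in place of phenyl, and even that step is unreadable because both of its compounds sit at limits. There is therefore no measured basis for predicting a step in either direction beyond the scatter in this assay.

With all three known values being limits, the expected value for compound 4 rests on the compounds themselves rather than on any trend; the estimated step is an at least 1.3-fold lower number from compound 3 to compound 4 (0.12 log units; that floor lies within the scatter). Compound 4 is expected to show around 100 ug/mL in this assay, within a range from 35 ug/mL to 200 ug/mL.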

Compound 4, solubility: 3 ug/mL
Estimate against measurement, compound 4: 33-fold (1.52 log units) above; the measured number lies below the stated range.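

In this assay, the amide-type nitrogen of compound 3 turns out to be a place where a single change can move the read-out a long way: 2-methylcyclopropyl in place of methyl gives an at least 44-fold lower number from compound 3 to compound 4 (1.64 log units; beyond the scatter). Within the data shown here, compound 4 is also the first compound here with a true number rather than a limit, and the one earlier step, among compounds 1 and 2, cannot be read, so this is the only readable step in the set. The real size of this step may be larger than printed, because compound 3 sits at a limit of the assay: the limit of >= 132 ug/mL in this assay, at which 1 of the 4 values shown sits.

From the compounds shown here alone, what remains open is which part of the new group goes with the step: its ring, its extra carbons, or its two defined stereocentres. An ethyl or a plain cyclopropyl group on the same nitrogen would begin to separate these, a chain ending in an amine would test a quite different kind of group there, and this single pair cannot show whether the same change would act alike on another core.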